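Cyclic sulfonamide in place of diethyl on the sulfonyl

The compounds below may be only part of what the source reports. "The series", "measured", "known", "first", "only" and "open" are said of these compounds alone.

Compound 1 `CC1(C)Oc2ccc(C(=O)c3ccccc3)cc2[C@@H](/N=C(\NC#N)Nc2ccc(Cl)cc2)[C@@H]1O` gives 7100 nM in a functional assay (aorta) with Rattus norvegicus as the target; on this read-out higher numbers stand for weaker inhibition and lower numbers for stronger inhibition.
Compound 2 `CC1(C)Oc2ccc(S(=O)(=O)c3ccccc3)cc2[C@@H](/N=C(\NC#N)Nc2ccc(Cl)cc2)[C@@H]1O` gives 500 nM in this assay.
Compound 3 `CCN(CC)S(=O)(=O)c1ccc2c(c1)[C@@H](/N=C(\NC#N)Nc1ccc(Cl)cc1)[C@H](O)C(C)(C)O2` gives 1100 nM in this assay.

Compound 3 stands second highest of the three numbers, with the step of a 2.2-fold higher number from compound 2 to compound 3 (0.34 log units; beyond the scatter) and the step of a 6.5-fold lower number from compound 1 to compound 3 (0.81 log units; beyond the scatter). Compound 4 `CC1CC(C)CN(S(=O)(=O)c2ccc3c(c2)[C@@H](/N=C(\NC#N)Nc2ccc(Cl)cc2)[C@H](O)C(C)(C)O3)C1` carries the change (3,5-dimethylpiperidin-1-yl in place of diethylamino on a sulfonyl sulfur). For the measured compounds named here, only one measured step touches the same sulfonyl sulfur: a 2.2-fold higher number from compound 2 to compound 3 (0.34 log units; beyond the scatter), a modest step, where a phenyl gave a lower number than a diethylamino. The other two steps, a 14-fold lower number from compound 1 to compound 2 (1.15 log units; beyond the scatter) and a 6.5-fold lower number from compound 1 to compound 3 (0.81 log units; beyond the scatter), concern exchanging the benzoyl and do not bear directly on this change. Going by the values given here, no measured pair shows what a cyclic amine on this sulfonyl does, so the expectation for compound 4 rests on a diethylamino and a phenyl only. Compound 4 is expected to give roughly a value between those two, estimated at 800 nM, with a range from 300 nM to 2500 nM. This estimate means a step of a 1.4-fold lower number from compound 3 to compound 4 (0.14 log units; within the scatter), expected to lie within or barely beyond the usual scatter.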

Compound 4, half-maximal inhibitory concentration: 32100 nM
Beside the measured number, compound 4's estimate is 40-fold (1.60 log units) below it; the whole stated range lies below it.
By their numbers in this assay, from the lowest: compound 2; then compound 3; then compound 1; then compound 4.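

In this assay, what sits on the sulfonyl sulfur turns out to matter far more than the earlier pair of phenyl and diethylamino suggested: 3,5-dimethylpiperidin-1-yl in place of diethylamino gives a 29-fold higher number from compound 3 to compound 4 (1.47 log units; beyond the scatter), and in place of phenyl it gives a 64-fold higher number from compound 2 to compound 4 (1.81 log units; beyond the scatter). The sulfonyl link alone therefore does not secure the lower numbers seen so far, since the benzoyl comparison, which favoured both earlier sulfonyl compounds, now reverses, with a 4.5-fold higher number from compound 1 to compound 4 (0.66 log units; beyond the scatter). Nothing available here explains why this group raises the number so sharply.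

The compounds shown leave open whether the loss follows from the ring itself or from its methyl groups. A plain piperidin-1-yl or a morpholin-4-yl on the same sulfonyl sulfur would help to separate these two readings.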